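Para-halogen returns to the benzamide of compound 3

This account rests on a few compounds, and the source may have more. Where it says the series, first, only, none or still open, it means among the compounds named here.

Compound 3 `Cc1ccccc1C(=O)Nc1cccc(-c2oc3cc(-c4ccc(F)cc4)ccc3c(=O)c2O)c1` gives 17600 nM in a functional assay on A549 cells (Homo sapiens) for antiproliferative activity, read by CCK-8 assay, with a stated time of 72 h (on this read-out higher numbers stand for weaker inhibition and lower numbers for stronger inhibition), the highest of the three numbers measured. Compound 1 `O=C(Nc1cccc(-c2oc3cc(-c4ccc(F)cc4)ccc3c(=O)c2O)c1)c1ccc(F)cc1` gives 6930 nM and compound 2 `O=C(Nc1cccc(-c2oc3cc(-c4ccc(F)cc4)ccc3c(=O)c2O)c1)c1ccc(Cl)cc1` gives 10800 nM. Compound 4 `O=C(Nc1cccc(-c2oc3cc(-c4ccc(F)cc4)ccc3c(=O)c2O)c1)c1ccc(Br)cc1` carries the change (4-bromophenyl in place of 2-methylphenyl on a carbonyl carbon). Among the compounds with values here, the steps that bear on it are a 2.5-fold higher number from compound 1 to compound 3 (0.40 log units; beyond the scatter) and a 1.6-fold higher number from compound 2 to compound 3 (0.21 log units; within the scatter), while a 1.6-fold higher number from compound 1 to compound 2 (0.19 log units; within the scatter) shows that moving between halogens changed little. Compound 4 is therefore expected to sit close to compound 2, with a step of a 1.8-fold lower number from compound 3 to compound 4 (0.25 log units; within the scatter) downward, in this assay. The estimate for compound 4 is 10000 nM, ranging from 4000 nM to 25000 nM.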

Compound 4, half-maximal inhibitory concentration: 13500 nM
Beside the measured number, compound 4's estimate is 1.4-fold (0.13 log units) below it, within the range that was stated.
By their numbers in this assay, from the lowest: compounds 1, 2, 4 and 3 (each within the scatter of the next, the first and the last beyond it).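

Bromo in place of chloro gives a 1.3-fold higher number from compound 2 to compound 4 (0.10 log units; within the scatter) and bromo in place of fluoro gives a 1.9-fold higher number from compound 1 to compound 4 (0.29 log units; within the scatter) in this assay, so fluoro, chloro and bromo on this ring cannot be told apart on this read-out. 4-Bromophenyl in place of 2-methylphenyl gives a 1.3-fold lower number from compound 3 to compound 4 (0.12 log units; within the scatter) and is not separated from 2-methylphenyl either, leaving a 2.5-fold higher number from compound 1 to compound 3 (0.40 log units; beyond the scatter) as the only step beyond the scatter. As far as these compounds go, whether an amine or a carboxylic acid on this ring would shift the number beyond the scatter stays open. Nothing shown gives a cause for these steps.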